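The source may hold more compounds than are shown below. What is called first, only, known or untested is meant among the compounds shown, and "the series" means these compounds.

Measured in a functional assay on MCF7 cells (Homo sapiens) for cytotoxicity, read by fluorescence, with a stated time of 72 h; a higher number here means a weaker inhibitor, a lower number a stronger inhibitor:
- compound 1 `Nc1n[nH]c(N)c1/N=N/c1ccncc1`: 4300 nM
- compound 2 `Nc1n[nH]c(N)c1/N=N/c1ccc(O)cc1`: 62000 nM
- compound 3 `Nc1n[nH]c(N)c1/N=N/c1cc[n+]([O-])cc1`: > 100000 nM (a limit of the assay, not a number)

Among the two true numbers, compound 2 stands highest at 62000 nM, so it is the weaker inhibitor. Compound 1 gives 4300 nM, and the gap between the two lies beyond the scatter.

Compound 4 `Cn1nc(N)c(/N=N/c2ccc(O)cc2)c1N` differs from compound 2 by one small change: methyl in place of hydrogen on an aromatic nitrogen, a methyl in place of hydrogen on an aromatic nitrogen. Going by the values given here, no measured pair here shows what this change does. The expected step in this assay is therefore small, with none beyond the scatter: a 1.0-fold lower number from compound 2 to compound 4 (0.01 log units; within the scatter). For compound 4 the estimated value is 60000 nM, with an expected range from 20000 nM to 100000 nM.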

Compound 4, half-maximal inhibitory concentration: > 100000 nM
Compound 4: only a limit was reported; the forecaster's own chance of this, stated with the estimate: 35%; at least 1.6-fold (0.22 log units) between middle value and limit.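

In this assay compound 4 gives > 100000 nM, a limit of the assay and not a number. The earlier compounds shown here all keep hydrogen on this aromatic nitrogen; methyl there gives an at least 1.6-fold higher number from compound 2 to compound 4 (0.20 log units; that floor lies within the scatter), so the change shows no sign of a stronger inhibitor, though this floor alone does not separate the two compounds. How large the step really is cannot be read, because compound 4 sits at a limit: the limit of > 100000 nM in this assay, at which 2 of the 4 values shown sit.

As far as these compounds go, whether methyl on this nitrogen would act the same way in compound 1 remains open. So does the effect of a longer chain or a carboxylic acid at this position.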